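The source may report more compounds than this note shows. Statements on the series, on what has been measured and on what is new or still open speak of the compounds shown alone.

Series notes on the step from compound 1 to compound 4.

Compound 1 `COc1cc(NC(C)CCCNC(=O)Nc2cccc(F)c2)c2ncccc2c1` carries a 3-fluorophenyl on an amide-type nitrogen. Among the compounds with values here, in a functional assay on NCI-H460 cells (Homo sapiens) for inhibition, read by MTT assay, with a stated time of 72 h (on this read-out higher numbers stand for weaker inhibition and lower numbers for stronger inhibition), compound 1 gives 24000 nM, the lowest of the three numbers measured so far. Compound 2 `COc1cc(NC(C)CCCNC(=O)NNC(=O)Nc2ccc(Cl)cc2)c2ncccc2c1` gives 63000 nM in this assay, and compound 3 `COc1cc(NC(C)CCCNC(=O)NNC(=O)Nc2cccc(F)c2)c2ncccc2c1` gives 50000 nM in this assay.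

Compound 4 `COc1cc(NC(C)CCCNC(=O)NNC(=O)Nc2cccc(Cl)c2)c2ncccc2c1` is not yet measured. Relative to compound 1 the change is ((3-chlorophenyl)carbamoyl)amino in place of 3-fluorophenyl on an amide-type nitrogen.

Within the data shown here, two measured steps bear on this change, since both also replace the 3-fluorophenyl of compound 1 with a ((halophenyl)carbamoyl)amino group: the step of a 2.6-fold higher number from compound 1 to compound 2 (0.42 log units; beyond the scatter) and the step of a 2.1-fold higher number from compound 1 to compound 3 (0.32 log units; beyond the scatter). Both went the same way, by a modest amount beyond the scatter. Within the urea pair the step of a 1.3-fold lower number from compound 2 to compound 3 (0.10 log units; within the scatter) shows that 4-chlorophenyl and 3-fluorophenyl are not separated, and no measured compound separates 3-chlorophenyl from either. A modest rise of the same kind is therefore expected for compound 4 in this assay, a 2.3-fold higher number from compound 1 to compound 4 (0.36 log units; beyond the scatter). For compound 4 the estimate in this assay is 55000 nM, expected to fall between 28000 nM and 110000 nM.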

Compound 4, half-maximal inhibitory concentration: 32000 nM
For compound 4 the middle estimate is 1.7-fold (0.24 log units) above the measured one; the range from low to high includes it.
By their numbers in this assay, from the lowest: compounds 1, 4, 3 and 2 (each within the scatter of the next, the first and the last beyond it).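

In this assay, a 1.3-fold higher number from compound 1 to compound 4 (0.12 log units; within the scatter) places the ((3-chlorophenyl)carbamoyl)amino group on the amide-type nitrogen without a step beyond the scatter, so carrying a ((halophenyl)carbamoyl)amino group at this place does not by itself separate a compound from compound 1. Compounds 2 and 3 each stand beyond the scatter from compound 1 and compound 4 goes against that pattern, yet compound 4 is not separated from either of them: chloro in place of fluoro on an aromatic carbon gives a 1.6-fold lower number from compound 3 to compound 4 (0.19 log units; within the scatter), and 3-chlorophenyl in place of 4-chlorophenyl gives a 2.0-fold lower number from compound 2 to compound 4 (0.29 log units; within the scatter), both within the scatter. Nothing available accounts for these numbers.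

Still open, as far as these compounds go, is whether an unsubstituted phenyl, or a phenyl carrying an amine or a carboxylic acid in place of the halogen, would give a step beyond the scatter at this place in this assay. Also open, from the compounds shown here alone, are how a 3-chlorophenyl set directly on the amide-type nitrogen would compare with compound 4, and whether a longer chain in place of the ((halophenyl)carbamoyl)amino group would be separated from compound 1.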